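Ring Nitrogen Substituent Exchange on a Substance-P Receptor Ligand

A few compounds are considered here, and "the series" means these few. Any claim that something is new, unique, unknown or untested is made for them only; others in the source may bear on it.

The account concerns three measured compounds and one not yet measured. Compound 1 `CN(Cc1cc(C(F)(F)F)cc(C(F)(F)F)c1)C(=O)[C@H]1CN(CC2CCCCC2)C[C@@H]1c1ccccc1` gives 62 nM in an assay on CHO cells for displacement of a labelled ligand from Substance-P receptor (Homo sapiens) (on this read-out higher numbers stand for weaker inhibition and lower numbers for stronger inhibition), the lowest of the three numbers. Compound 3 `CC(C)(C)OC(=O)N1C[C@H](C(=O)NCc2cc(C(F)(F)F)cc(C(F)(F)F)c2)[C@@H](c2ccccc2)C1` gives 142 nM in this assay, a number higher than that of compound 1 by more than the usual scatter. Compound 2 `CC(C)(C)OC(=O)N1CC[C@H](c2ccccc2)[C@@H](C(=O)NCc2cc(C(F)(F)F)cc(C(F)(F)F)c2)C1` gives 450 nM in this assay, the furthest from compound 1. Among the compounds with values here, no single-point step between measured compounds is available.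

Compound 4 `CN(Cc1cc(C(F)(F)F)cc(C(F)(F)F)c1)C(=O)[C@H]1CN(C(=O)C2CCNCC2)C[C@@H]1c1ccccc1` differs from compound 1 in one place: (piperidin-4-yl)carbonyl in place of cyclohexylmethyl on an amine nitrogen in a ring. Compound 2 and compound 3, which each carry a carbonyl on the ring nitrogen, give higher numbers than compound 1, so the expected step from compound 1 to compound 4 is a weakening beyond the scatter, as in a 3.2-fold higher number from compound 1 to compound 4 (0.51 log units; beyond the scatter). The estimate for compound 4 in this assay is 200 nM, expected to fall between 60 nM and 700 nM.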

Compound 4, half-maximal inhibitory concentration: 4.1 nM
Estimate against measurement, compound 4: 49-fold (1.69 log units) above, outside the stated range (below it).
By their numbers in this assay, from the lowest: compound 4; then compound 1; then compound 3; then compound 2.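

In this assay, within the data shown here, the exchange of cyclohexylmethyl for (piperidin-4-yl)carbonyl on the ring nitrogen gives a 15-fold lower number from compound 1 to compound 4 (1.18 log units; beyond the scatter), the first single-place step at this position. It shows that this nitrogen can carry a carbonyl-linked group in place of a carbon-linked one, and that the entering group, with its second ring nitrogen, gives a large gain in this assay rather than a loss. No measurement shown explains the size or direction of this step.

The change alters the link and the ring at once, so the compounds shown do not separate the contribution of the carbonyl from that of the ring nitrogen. Going by these compounds, what cyclohexylcarbonyl or (piperidin-4-yl)methyl would give on this nitrogen remains open, and either would divide the step between those two parts.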